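The source may hold more compounds than are shown below. What is called first, only, known or untested is meant among the compounds shown, and "the series" means these compounds.

Measured so far:
compound 1, `COc1cc(-c2cc(/C=C/C(=O)c3ccc(N)cc3)[nH]n2)cc(OC)c1OC` — 8660 nM
compound 2, `COc1cc(-c2cc(/C=C/C(=O)c3ccc(Cl)c(Cl)c3)[nH]n2)cc(OC)c1OC` — a limit, > 100000 nM

Compound 2 gives > 100000 nM in a functional assay on UACC-257 cells (Homo sapiens) for inhibition, read by sulforhodamine B assay, with a stated time of 48 h; a lower number here means that less compound is tolerated, a higher number that more compound is tolerated; that value is a limit of the assay and not a number, and the limit of > 100000 nM in this assay, at which 1 of the 2 values shown sits, marks where it sits. Compound 1 gives 8660 nM in this assay. Among the compounds with values here, the single measured step, an at least 11-fold higher number from compound 1 to compound 2 (1.06 log units; beyond the scatter), is large and beyond the scatter, and it shows that the group on the carbonyl carbon can move the number a great deal. Compound 3, `COc1ccc(C(=O)/C=C/c2cc(-c3cc(OC)c(OC)c(OC)c3)n[nH]2)cc1OC`, is next to be measured; (3,4-dimethoxyphenyl in place of 3,4-dichlorophenyl on a carbonyl carbon). Within the data shown here, no measured step carries this change, so the step from compound 1 to compound 2 bears on it only as a measure of how far this position can shift the number, without fixing the direction. The step from compound 2 to compound 3 is expected to be an at least 3.3-fold lower number from compound 2 to compound 3 (0.52 log units; beyond the scatter). Compound 3 is estimated at 30000 nM, in a wide range from 6000 nM to 100000 nM.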

Compound 3, concentration lethal to 50% of the cells: 5370 nM
Estimate against measurement, compound 3: 5.6-fold (0.75 log units) above; the whole stated range lies above it.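

On the carbonyl carbon, 3,4-dimethoxyphenyl in place of 3,4-dichlorophenyl gives an at least 18-fold lower number from compound 2 to compound 3 (1.27 log units; beyond the scatter) in this assay, so the number follows the identity of the group and not merely the presence of two substituents on the phenyl ring. Compound 2 stands at a limit of the assay and not at a number: the limit of > 100000 nM in this assay, at which 1 of the 3 values shown sits. The 4-aminophenyl and 3,4-dimethoxyphenyl groups are not separated, with a 1.6-fold lower number from compound 1 to compound 3 (0.21 log units; within the scatter); of the three groups, only 3,4-dichlorophenyl gives the high number.

Still open, on these data alone, is whether a 4-chlorophenyl, a 4-methoxyphenyl or a 4-carboxyphenyl group on the carbonyl carbon would stand with 3,4-dichlorophenyl or with the other two. Also open, as far as these compounds go, is how far the real value of compound 2 lies past its limit.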